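The compounds below may be only part of what the source reports. "The series", "measured", "known", "first", "only" and "open" are said of these compounds alone.

Measured compounds:
compound 1 `COc1cc(-c2nnc3n2NC(c2cccs2)C(C(=O)c2ccc(C)cc2)S3)cc(OC)c1OC` — 5090 nM
compound 2 `COc1cc(-c2nnc3n2NC(c2ccco2)C(C(=O)c2ccc(F)c(F)c2)S3)cc(OC)c1OC` — 36000 nM
compound 3 `COc1cc(-c2nnc3n2NC(c2ccco2)C(C(=O)c2cccc(Br)c2)S3)cc(OC)c1OC` — 63900 nM

In a functional assay on PC-3 cells (Homo sapiens) for cytotoxicity, read by MTT assay, with a stated time of 48 h (a lower number here means a stronger inhibitor, a higher number a weaker inhibitor), compound 2 gives the second highest of the three numbers. Its nearest neighbour is compound 3, which differs only on the carbonyl carbon: a 1.8-fold higher number from compound 2 to compound 3 (0.25 log units; within the scatter). The furthest is compound 1, whose number is lower by more than the usual scatter, but compound 1 and compound 2 differ in two places at once, so nothing is known about what either change contributes on its own.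

The step now considered leads from compound 2 to compound 4 `COc1cc(-c2nnc3n2NC(c2ccco2)C(C(=O)c2ccc(C)cc2)S3)cc(OC)c1OC`. The change is 4-methylphenyl in place of 3,4-difluorophenyl on a carbonyl carbon. Compound 4 thus carries the same 4-methylphenyl group as compound 1 while keeping the furanyl group of compound 2.

For the measured compounds named here, only one measured step touches the same position, and it stayed within the scatter: a 1.8-fold higher number from compound 2 to compound 3 (0.25 log units; within the scatter). On the other hand compound 1, which also bears the 4-methylphenyl group, gives 5090 nM in this assay, and its difference from compound 2 goes beyond the scatter. Going by the values given here, an aryl change of this kind has therefore once been seen to do little, while the only compound with this particular group sits clearly lower; the expectation for compound 4 is a lower number than compound 2, a 2.6-fold lower number from compound 2 to compound 4 (0.41 log units; beyond the scatter), with wide uncertainty. The estimate for compound 4 is 14000 nM, with a range from 4500 nM to 45000 nM.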

Compound 4, half-maximal inhibitory concentration: 7500 nM
Compound 4: middle estimate off by 1.9-fold (0.27 log units), on the high side; the measured number falls inside the stated range.
By their numbers in this assay, from the lowest: compounds 1 and 4 (each within the scatter of the next); then compounds 2 and 3 (each within the scatter of the next).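

In this assay, for the compounds shown here, the change on the carbonyl carbon now moves the number beyond the scatter, with a 4.8-fold lower number from compound 2 to compound 4 (0.68 log units; beyond the scatter) and with an 8.5-fold lower number from compound 3 to compound 4 (0.93 log units; beyond the scatter) as well, whereas the only earlier step at this place, a 1.8-fold higher number from compound 2 to compound 3 (0.25 log units; within the scatter), did not. Among the furan-2-yl compounds the aryl group on the carbonyl carbon therefore matters, and 4-methylphenyl gives a lower number than either 3,4-difluorophenyl or 3-bromophenyl. The other position also gets its first reading in one place, a 1.5-fold higher number from compound 1 to compound 4 (0.17 log units; within the scatter), so with 4-methylphenyl on the carbonyl carbon, furan-2-yl and thiophen-2-yl cannot be told apart here.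

On these data alone, whether the methyl group itself matters remains open, since these compounds do not show how an unsubstituted phenyl, a methoxy group, an amine or a carboxylic acid on that phenyl ring would read, or whether the same order of aryl groups would hold with thiophen-2-yl in place of furan-2-yl. Why 4-methylphenyl differs from the other two aryl groups also stays unexplained, as no other measurement bears on it.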